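A 2-chlorophenyl variant of the shared core

The source may hold more compounds than are shown below. What is called first, only, known or untested is meant among the compounds shown, and "the series" means these compounds.

Measured so far, in a functional assay on PC-12 cells (Rattus norvegicus) for cytotoxicity, read by MTT assay, with stated times of 2 h and 24 h, tested at 5 uM; on this read-out higher numbers stand for a stronger effect at the one concentration tested and lower numbers for a weaker effect:
compound 1, `Oc1cc(C(F)(F)F)ccc1-c1nc(-c2ccccc2O)n(-c2ccc(Cl)cc2)n1`, gives 87.3%
compound 2, `Oc1cc(C(F)(F)F)ccc1-c1nc(-c2ccccc2O)n(-c2ccc(OC(F)(F)F)cc2)n1`, gives 84.9%

For the measured compounds named here, compound 2 holds the lower of the two numbers so far, and its nearest neighbour is compound 1; the only measured step, a number 2.4 percentage points lower from compound 1 to compound 2 (within the scatter), lies within the scatter, so the two cannot be ranked against each other in this assay.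

Compound 3, `Oc1cc(C(F)(F)F)ccc1-c1nc(-c2ccccc2O)n(-c2ccccc2Cl)n1`, differs from compound 2 in a single place: 2-chlorophenyl in place of 4-(trifluoromethoxy)phenyl on an aromatic nitrogen. Going by the values given here, no measured step covers this exchange. Among the compounds with values here, the one step that exists, a number 2.4 percentage points lower from compound 1 to compound 2 (within the scatter), changes a group on the same phenyl ring but not in the same way, and it was small. Within the data shown here, with no step in hand that reaches beyond the scatter, the reasonable expectation for compound 3 in this assay is no change beyond the scatter, which the estimated step of a number 0.9 percentage points lower from compound 2 to compound 3 (within the scatter) expresses. Compound 3 is therefore expected to give about 84% in this assay, with an estimated range from 72% to 93%.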

Compound 3, a percentage reported as activity, at one concentration (the size of the read-out at that concentration, not a potency): 90.6%
Compound 3: middle estimate off by 6.6 percentage points, on the low side, and the stated range covers the measured number.
By their numbers in this assay, from the lowest: compounds 2, 1 and 3 (each within the scatter of the next).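

In this assay, for the compounds shown here, the exchange of 4-(trifluoromethoxy)phenyl for 2-chlorophenyl on the aromatic nitrogen gives a number 5.7 percentage points higher from compound 2 to compound 3 (within the scatter) and is the first step at this position that removes the trifluoromethoxy group while also changing the place of the substituent on the phenyl ring. The exchange of 4-chlorophenyl for 2-chlorophenyl gives a number 3.3 percentage points higher from compound 1 to compound 3 (within the scatter) and isolates the place of the chlorine on that ring, so all three aryl groups now stand within the scatter of one another and neither exchange separates the compounds at the one concentration tested. Nothing available here explains these numbers or bears on what lies behind them.

The compounds shown all carry a phenyl ring with a single chloro or trifluoromethoxy substituent on this nitrogen, so it remains open whether an amine or a carboxylic acid on that ring, or a longer alkyl chain in place of the ring, would move the read-out beyond the scatter. Because this read-out comes from one concentration, these compounds also leave open whether their potencies differ.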